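Extending the Chain of Compound 3

This account rests on a few compounds, and the source may have more. Where it says the series, first, only, none or still open, it means among the compounds named here.

In a functional assay on HCT-116 cells (Homo sapiens) for antiproliferative activity, read by MTT assay, with a stated time of 48 h (on this read-out lower numbers stand for stronger inhibition and higher numbers for weaker inhibition), compound 1 `CC(CCO)n1cnc2c(Cl)nc(F)nc21` gives 19800 nM and compound 2 `CCC(CCO)n1cnc2c(Cl)nc(F)nc21` gives 18900 nM while compound 3 `CCCCC(CCO)n1cnc2c(Cl)nc(F)nc21` gives 13500 nM in the same range, as all three lie within the scatter of one another. Compound 4 `CCCCCC(CCO)n1cnc2c(Cl)nc(F)nc21` differs from compound 3 by methyl in place of hydrogen on a saturated chain carbon, five bonds along the chain from an aromatic nitrogen. The closest guides are the earlier changes on this same chain: a 1.0-fold lower number from compound 1 to compound 2 (0.02 log units; within the scatter) and a 1.4-fold lower number from compound 2 to compound 3 (0.15 log units; within the scatter) and overall a 1.5-fold lower number from compound 1 to compound 3 (0.17 log units; within the scatter) with each staying within the scatter. No step beyond the scatter is therefore expected in this assay. The expected change is a 1.0-fold lower number from compound 3 to compound 4 (0.02 log units; within the scatter) and no larger. For compound 4 the estimate is 13000 nM (expected range 7000 nM to 22000 nM).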

Compound 4, half-maximal inhibitory concentration: 8660 nM
Estimate against measurement, compound 4: 1.5-fold (0.18 log units) above; low and high end bracket the measured number.
By their numbers in this assay, from the lowest: compounds 4, 3, 2 and 1 (each within the scatter of the next, the first and the last beyond it).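

In this assay, methyl in place of hydrogen at this position gives a 1.6-fold lower number from compound 3 to compound 4 (0.19 log units; within the scatter), so this single change does not separate compound 4 from compound 3. Going by these compounds alone, the longer chain of compound 4 does separate it from the shorter-chain compounds, with steps beyond the scatter for the first time: a 2.2-fold lower number from compound 2 to compound 4 (0.34 log units; beyond the scatter) and a 2.3-fold lower number from compound 1 to compound 4 (0.36 log units; beyond the scatter). The methyl change also gives matching steps at two places on the chain: the same change on two cores in this assay, a 1.0-fold lower number (0.02 log units; within the scatter) from compound 1 to compound 2 and a 1.6-fold lower number (0.19 log units; within the scatter) from compound 3 to compound 4, 1.5-fold (0.17 log units) apart, within the scatter of two such steps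

As far as these compounds go, whether a longer chain or an amine in this same place would take the number lower remains open.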